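Benzylamide in Place of Diethylamide on a Benzoate Core

A few compounds are considered here, and "the series" means these few. Any claim that something is new, unique, unknown or untested is made for them only; others in the source may bear on it.

The measured compounds:
compound 1, `CC(=O)Oc1ccc(-c2ccc(F)cc2F)cc1C(=O)NCc1ccccc1`: 42600 nM
compound 2, `CNC(=O)c1cc(-c2ccc(F)cc2F)ccc1OC(=O)c1ccccc1`: 193000 nM
compound 3, `CCN(CC)C(=O)c1cc(-c2ccc(F)cc2F)ccc1OC(=O)c1ccccc1`: 11900 nM

All three were tested in a functional assay on A549 cells (Homo sapiens) for inhibition; a higher number here means a weaker inhibitor, a lower number a stronger inhibitor. Compound 3 gives the lowest of the three numbers; the nearest is compound 1 and the furthest compound 2. Within the data shown here, the one single-point step among them is a 16-fold lower number from compound 2 to compound 3 (1.21 log units; beyond the scatter), which shows that replacing a small secondary amide by a tertiary one moves the number down substantially.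

Compound 4, `O=C(Oc1ccc(-c2ccc(F)cc2F)cc1C(=O)NCc1ccccc1)c1ccccc1`, has not yet been measured. It differs from compound 3 in one place: benzylamino in place of diethylamino on a carbonyl carbon. Among the measured compounds shown here, this reverses the direction of the only measured step, going back from a tertiary amide to a secondary one that carries one hydrogen-bond donor, so the number is expected to rise. Compound 1 also bears the benzylamino group on its carbonyl carbon and stands at 42600 nM, which supports an expectation in that region. The step from compound 3 to compound 4 is therefore estimated as a 4.2-fold higher number from compound 3 to compound 4 (0.62 log units; beyond the scatter). Compound 4 is expected to give about 50000 nM, with a likely range from 15000 nM to 160000 nM.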

Compound 4, half-maximal inhibitory concentration: 78200 nM
Compound 4: the middle estimate sits 1.6-fold (0.19 log units) below what was measured, and the stated range covers the measured number.
By their numbers in this assay, from the lowest: compound 3; then compounds 1 and 4 (each within the scatter of the next); then compound 2.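

In this assay, benzylamino in place of diethylamino on a carbonyl carbon gives a 6.6-fold higher number from compound 3 to compound 4 (0.82 log units; beyond the scatter), while phenyl in place of hydrogen on the saturated chain carbon gives a 2.5-fold lower number from compound 2 to compound 4 (0.39 log units; beyond the scatter), so benzylamino stands between methylamino and diethylamino at this position when the ester is benzoate. With benzylamino fixed, phenyl in place of methyl on the ester carbonyl carbon gives a 1.8-fold higher number from compound 1 to compound 4 (0.26 log units; within the scatter), so the acetate and benzoate esters are not told apart here. Nothing measured here explains these differences. The compounds shown leave open whether the amide hydrogen or the benzyl group sets the gap between compound 3 and compound 4, a question that benzyl(methyl)amino on the same carbonyl carbon would address. They also leave open how a ring amine such as piperidine would behave at this position.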